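The compounds below may be only part of what the source reports. "The series", "measured", "known", "first", "only" and "open" are said of these compounds alone.

Working notes start from compound 2 (`Clc1ccc(-c2cn3nc(-c4ccccc4)nc3s2)cc1`). In a functional assay on A549 cells (Homo sapiens) for inhibition, read by sulforhodamine B assay, with a stated time of 48 h, tested at 10 uM (on this read-out lower numbers stand for less inhibition of growth and higher numbers for more inhibition of growth at the one concentration tested), compound 2 gives 36% and stands second highest of three. Compound 1 (`COc1ccc(-c2nc3sc(-c4ccccc4)cn3n2)cc1`) gives 49%, and compound 3 (`COc1ccc(-c2nc3sc(-c4ccc(Cl)cc4)cn3n2)cc1`) gives -30% in the same read-out. Compound 4 (`c1ccc(-c2nc3sc(-c4ccccc4)cn3n2)cc1`) has hydrogen in place of chloro on an aromatic carbon. The closest evidence is the opposite change, chloro in place of hydrogen, which gave a number 79 percentage points lower from compound 1 to compound 3 (beyond the scatter) in the presence of methoxy. Methoxy in place of hydrogen gave a number 66 percentage points lower from compound 2 to compound 3 (beyond the scatter) with chloro present. Both steps end at compound 3, which carries both groups, whereas compound 2 has no methoxy, so only a modest rise is expected. The estimated step is a number 14 percentage points higher from compound 2 to compound 4 (beyond the scatter) (well short of the size of those steps). The estimate for compound 4 is 50% (expected range 20% to 80%).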

Compound 4, percent growth inhibition at one concentration: 10%
Beside the measured number, compound 4's estimate is 40 percentage points above it, and the stated range ends above it.
By their numbers in this assay, from the lowest: compound 3; then compound 4; then compound 2; then compound 1.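

Hydrogen in place of chloro gives a number 26 percentage points lower from compound 2 to compound 4 (beyond the scatter), so without methoxy, chloro goes with more growth inhibition, the reverse of its step in the presence of methoxy. Hydrogen in place of methoxy gives a number 39 percentage points lower from compound 1 to compound 4 (beyond the scatter), so methoxy without chloro also goes with more growth inhibition. Each group raises the number alone, yet compound 3, carrying both, has the lowest number, so the steps do not add: the same change on two cores in this assay, a number 79 percentage points lower (beyond the scatter) from compound 1 to compound 3 and a number 26 percentage points higher (beyond the scatter) from compound 4 to compound 2, 105 percentage points apart, beyond the scatter of two such steps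

On these data alone, whether an amine or a carboxylic acid at this place would follow chloro remains open. So does whether either group, paired with methoxy, would repeat the fall seen at compound 3.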